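This account rests on a few compounds, and the source may have more. Where it says the series, first, only, none or still open, it means among the compounds named here.

Measured compounds:
compound 1 `ClCc1ccccc1Cn1cnc2c(Cl)nc(Cl)nc21` gives 9550 nM
compound 2 `ClCc1ccccc1Cn1cnc2ncnc(Cl)c21` gives 57500 nM

Of the compounds shown here, two sharing one core have been measured in a functional assay on A498 cells (Homo sapiens) for cytotoxicity, read by sulforhodamine B assay, with a stated time of 48 h; a lower number here means that less compound is tolerated, a higher number that more compound is tolerated. Compound 2 stands at the higher of the two numbers, with compound 1 well below it, a gap that is beyond the usual scatter, so compound 2 is the better tolerated of the pair in this assay.

Compound 3 `ClCc1ccccc1Cn1cnc2nc(Cl)nc(Cl)c21` has not yet been measured there. It differs from compound 2 in one place: chloro in place of hydrogen on an aromatic carbon. Going by the values given here, no measured pair shows what such an added chloro does on this core, but compound 1, which carries two chloro groups, gives the lower number at 9550 nM, so a drop from compound 2 toward less tolerance is the expected direction, of a size that is estimated as a 3.8-fold lower number from compound 2 to compound 3 (0.58 log units; beyond the scatter). Compound 3 is therefore expected to give about 15000 nM, within a range from 4000 nM to 50000 nM.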

Compound 3, concentration lethal to 50% of the cells: 19500 nM
The estimate for compound 3 lay 1.3-fold (0.11 log units) below the measured number; the range from low to high includes it.
By their numbers in this assay, from the lowest: compound 1; then compound 3; then compound 2.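

In this assay, going by these compounds alone, compounds 2 and 3 form the first pair on the shared core that differs in one place, and so give the first direct reading of chloro in place of hydrogen on this aromatic carbon between two ring nitrogen atoms: a 2.9-fold lower number from compound 2 to compound 3 (0.47 log units; beyond the scatter), a modest step that is beyond the scatter. Compound 1 could not show this, as it differs from compound 2 in more than one place. Nothing available accounts for why the added chloro lowers the number.

The compounds shown leave open whether this position responds only to chloro or also to other groups, such as an amine or a methoxy group. They also leave open whether the same change would give a step of similar size on the core of compound 1.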